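Thioether Citrate Analogues: Tail Aryl Substituent Survey

A few compounds are considered here, and "the series" means these few. Any claim that something is new, unique, unknown or untested is made for them only; others in the source may bear on it.

Measured so far:
Compound 2, `O=C(O)CC(O)(CSCCCCCCc1ccc(-c2ccccc2)cc1)C(=O)O` — 38000 nM
Compound 1, `O=C(O)CC(O)(CSCCCCCCc1ccc(Cl)c(Cl)c1)C(=O)O` — 110000 nM

In an assay on isolated protein for inhibition of ATP-citrate synthase (Rattus norvegicus) (a higher number here means a weaker inhibitor, a lower number a stronger inhibitor), compound 2 gives 38000 nM, the lowest of the two numbers available. Compound 1 gives 110000 nM, a gap from compound 2 that lies beyond the scatter, so compound 2 stands as the stronger of the two on the numbers shown. For the measured compounds named here, no pair of measured compounds differs in a single place, so no direct step can be read off.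

Compound 3, `O=C(O)CC(O)(CSCCCCCCc1ccc(F)cc1)C(=O)O`, differs from compound 2 by fluoro in place of phenyl on an aromatic carbon. The shared core and the six-carbon chain are unchanged. Going by the values given here, the only guidance is indirect: compound 1, which carries small halogen substituents rather than the phenyl, sits higher in this assay at 110000 nM, and compound 3 likewise carries a small halogen in place of the phenyl. The expectation is therefore a weakening, with the step of a 2.9-fold higher number from compound 2 to compound 3 (0.46 log units; beyond the scatter) estimated to exceed the scatter. Compound 3 is estimated at 110000 nM, with a range from 45000 nM to 280000 nM.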

Compound 3, inhibition constant: 120000 nM
Beside the measured number, compound 3's estimate is 1.1-fold (0.04 log units) below it, and the stated range covers the measured number.
By their numbers in this assay, from the lowest: compound 2; then compounds 1 and 3 (each within the scatter of the next).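

In this assay, for the compounds shown here, the exchange of phenyl for fluoro on this aromatic carbon gives a 3.2-fold higher number from compound 2 to compound 3 (0.50 log units; beyond the scatter) and is the first direct reading at this position: the phenyl, with its six-membered aromatic ring of carbon only, goes with the stronger inhibition of the pair. The two halogen-bearing tails are not separated, since 4-fluorophenyl in place of 3,4-dichlorophenyl gives a 1.1-fold higher number from compound 1 to compound 3 (0.04 log units; within the scatter) in this assay, so on these compounds the single fluoro and the dichloro pattern stand level, and only the phenyl-bearing compound 2 stands apart from them. No measurement at hand accounts for the gain that goes with the phenyl.

On these data alone, whether the gain depends on an aromatic ring as such remains open, as a cyclohexyl, a benzyl or a pyridyl at the same carbon would test that against compound 2. Also open, as far as these compounds go, is how the phenyl tail responds to a shorter or longer chain, and whether a methoxy, an amine or a carboxylic acid on the ring would move the number in either direction.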